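A Second Methoxy Group Added to Compound 1

The compounds below may be only part of what the source reports. "The series", "measured", "known", "first", "only" and "open" are said of these compounds alone.

Measured compounds:
compound 1 `COc1ccc(/C(Cl)=C/C=C(\C#N)C(=O)c2c[nH]c3ccc(Br)cc23)cc1`: 56.2%
compound 2 `COc1ccc(/C(Cl)=C/C=C(\C#N)C(=O)c2c[nH]c3ccc(OC)cc23)cc1`: 41.6%

In a functional assay for inhibition, read by Griess assay, with a stated time of 150 min, tested at 1 mM (a higher number here means more inhibition at the concentration tested (going by the name of the read-out), a lower number less inhibition), compound 1 gives 56.2%, the highest of the two numbers shown. Compound 2 gives 41.6%. Among the measured compounds shown here, the only measured step, a number 14.6 percentage points lower from compound 1 to compound 2 (beyond the scatter), is methoxy in place of bromo on an aromatic carbon, a change on the part of the core that carries the bromo group of compound 1.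

Compound 3 `COc1ccc(/C(Cl)=C/C=C(\C#N)C(=O)c2c[nH]c3ccc(Br)cc23)cc1OC` differs from compound 1 by methoxy in place of hydrogen on an aromatic carbon. The new group enters ortho to a methoxy group and meta to a large group, so the change sits on a different aromatic ring from the one varied in the measured step. For the measured compounds named here, no measured step concerns this ring, so the single step between compound 1 and compound 2 bears on it only in showing that a change elsewhere moved the read-out modestly. With nothing directly comparable, a step within the scatter, in either direction, is expected for this assay. The expected step is a number 2.2 percentage points lower from compound 1 to compound 3 (within the scatter). Compound 3 is thus estimated to give 54%, with a range from 35% to 72%.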

Compound 3, a percentage reported as inhibition, at one concentration (the size of the read-out at that concentration, not a potency): 57.5%
The estimate for compound 3 lay 3.5 percentage points below the measured number, and the stated range covers the measured number.
By their numbers in this assay, from the lowest: compound 2; then compounds 1 and 3 (each within the scatter of the next).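

The added methoxy is the first change shown on this ring, ortho to a methoxy group and meta to a large group, and in this assay the step is a number 1.3 percentage points higher from compound 1 to compound 3 (within the scatter). This places compounds 1 and 3 level with each other, so on the core of compound 1 this position accepts methoxy in place of hydrogen with no change in the read-out that can be told from the scatter. The earlier step, a number 14.6 percentage points lower from compound 1 to compound 2 (beyond the scatter), lay beyond the scatter and concerned the other aromatic ring, so of the two places varied so far, only that one has moved the read-out, and no measurement shown offers an explanation for the difference between them.

The compounds shown leave open whether a hydroxyl group, a fluorine atom or a longer chain such as ethoxy at this position would also stay level with compound 1. They also leave open whether the same added methoxy would give a similar step on the core of compound 2, and, with every number taken at one concentration, how these compounds compare in potency.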